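The compounds below may be only part of what the source reports. "The series", "measured", "known", "first", "only" and "open" are said of these compounds alone.

Three stereoisomers of a single structure have been measured in an assay on isolated protein for inhibition of eIF-2-alpha kinase GCN2 (Homo sapiens); on this read-out lower numbers stand for stronger inhibition and higher numbers for weaker inhibition. Compound 1 `COCCNC(=O)[C@@H]1CC[C@H](Nc2ncc3c(Br)nn(-c4ccc5ncccc5c4)c3n2)C1` gives 923 nM. Compound 2 `COCCNC(=O)[C@H]1CC[C@H](Nc2ncc3c(Br)nn(-c4ccc5ncccc5c4)c3n2)C1` gives 144 nM, and compound 3 `COCCNC(=O)[C@@H]1CC[C@@H](Nc2ncc3c(Br)nn(-c4ccc5ncccc5c4)c3n2)C1` gives 5 nM. The steps between them are a 6.4-fold lower number from compound 1 to compound 2 (0.81 log units; beyond the scatter), a 180-fold lower number from compound 1 to compound 3 (2.27 log units; beyond the scatter) and a 29-fold lower number from compound 2 to compound 3 (1.46 log units; beyond the scatter); each pair is the same set of atoms and bonds arranged differently the fact that compounds 1 and 2 differ only in the configuration as drawn the fact that compounds 1 and 3 differ only in the configuration as drawn (the fact that compounds 2 and 3 differ only in the configuration as drawn). Compound 3 therefore stands lowest of the three numbers, with compound 2 nearest and compound 1 furthest.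

Compound 4 `COCCS(=O)(=O)N[C@@H]1CC[C@@H](Nc2ncc3c(Br)nn(-c4ccc5ncccc5c4)c3n2)C1` differs from compound 3 by ((2-methoxyethyl)sulfonyl)amino in place of (2-methoxyethyl)carbamoyl on a saturated ring carbon. Within the data shown here, none of the measured steps concerns such an exchange of groups; all three turn on configuration alone and so say nothing directly about it. They do show the series responds strongly to the arrangement at the two stereocentres, which compound 4 keeps as in compound 3. Among the measured compounds shown here, with no direct precedent, a modest rise in the number is expected, and the expected step is a 3.0-fold higher number from compound 3 to compound 4 (0.48 log units; beyond the scatter). Compound 4 is estimated at 15 nM, with a range from 3 nM to 80 nM.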

Compound 4, half-maximal inhibitory concentration: 55 nM
Estimate against measurement, compound 4: 3.7-fold (0.56 log units) below; the measured number falls inside the stated range.
By their numbers in this assay, from the lowest: compound 3; then compound 4; then compound 2; then compound 1.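

The earlier compounds shown here showed only that this assay responds to configuration; this exchange shows that the group on the saturated ring carbon matters as well, with ((2-methoxyethyl)sulfonyl)amino in place of (2-methoxyethyl)carbamoyl giving an 11-fold higher number from compound 3 to compound 4 (1.04 log units; beyond the scatter). Compound 4 keeps the configuration of compound 3, so this step turns on the exchange of groups alone, and the position does not treat the two groups as equivalent even though both carry a 2-methoxyethyl end. Nothing in the evidence at hand bears on why the number rises.

Going by these compounds, how an amine, a carboxylic acid or a longer chain would read on this ring carbon remains open. Also open, on these data alone, is whether the other stereoisomers of compound 4 would follow the order seen across compound 1, compound 2 and compound 3.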